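Adding a Methyl at the Amine: Expectations for Compound 4

The source may report more compounds than this note shows. Statements on the series, on what has been measured and on what is new or still open speak of the compounds shown alone.

Compound 1 `C/N=C(/NC#N)C1=CC(C)(C)Oc2ccc([N+](=O)[O-])cc21`: 23.4 nM
Compound 2 `CC/N=C(/NC#N)C1=CC(C)(C)Oc2ccc([N+](=O)[O-])cc21`: 170 nM
Compound 3 `CCN(C)/C(=N\C#N)C1=CC(C)(C)Oc2ccc([N+](=O)[O-])cc21`: 178 nM

All three were tested in a functional assay (Trachealis) with Cavia porcellus as the target; on this read-out lower numbers stand for an effect already at smaller amounts and higher numbers for an effect only at larger amounts of compound. Compound 1 shows the lowest number, and its steps to the other two lie beyond the scatter; the numbers of compound 2 and compound 3 lie within the scatter of each other.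

The change from compound 1 to compound 2 is methyl in place of hydrogen on a saturated chain carbon bound to a double-bonded nitrogen. It made a 7.3-fold higher number from compound 1 to compound 2 (0.86 log units; beyond the scatter). How the core of compound 3 differs from that of compound 1 is not broken down here; their values differ beyond the scatter.

Compound 4 `CCN(CC)/C(=N\C#N)C1=CC(C)(C)Oc2ccc([N+](=O)[O-])cc21` has not yet been measured in this assay. It differs from compound 3 by methyl in place of hydrogen on a saturated chain carbon bound to an amine nitrogen. Within the data shown here, this is the same kind of change as the one from compound 1 to compound 2, but not the same: in the earlier pair the carbon is bound to a double-bonded nitrogen, here it is bound to an amine nitrogen. Among the measured compounds shown here, the expected step is a 2.8-fold higher number from compound 3 to compound 4 (0.45 log units; beyond the scatter), smaller than but in the direction of a 7.3-fold higher number from compound 1 to compound 2 (0.86 log units; beyond the scatter), because a 7.3-fold higher number from compound 1 to compound 2 (0.86 log units; beyond the scatter) is the only measured guide and the place differs. For compound 4 the estimated value is 500 nM, likely between 200 nM and 1500 nM.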

Compound 4, half-maximal effective concentration: < 31700 nM
Compound 4: only a limit was reported; the forecaster's own chance of this, stated with the estimate: 5%; the middle value does not contradict the limit.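

In this assay compound 4 gives < 31700 nM, which is a limit of the assay and not a number. The step from compound 3 to compound 4 cannot be read from it. The compounds shown leave open whether methyl in place of hydrogen on a saturated chain carbon bound to an amine nitrogen raises the number, lowers it or leaves it unchanged.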